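Swapping chloro for bromo in compound 3

A few compounds are considered here, and "the series" means these few. Any claim that something is new, unique, unknown or untested is made for them only; others in the source may bear on it.

Measured in a functional assay on A549 cells (Homo sapiens) for antiproliferative activity, read by MTT assay, with a stated time of 48 h; a higher number here means a weaker inhibitor, a lower number a stronger inhibitor:
Compound 1 `Cc1cccn2cc(-c3nnc(-c4ccccc4I)o3)nc12` gives 33400 nM
Compound 2 `Cc1cc(Br)c2nc(-c3nnc(-c4ccccc4)o3)cn2c1` gives 14500 nM
Compound 3 `Cc1cc(Br)c2nc(-c3nnc(-c4ccc(Cl)cc4)o3)cn2c1` gives 43500 nM

Among these three, compound 3 has a number within the scatter of compound 1 and beyond the scatter of compound 2, so it sits at the weak end of the set, level with compound 1. The next compound, compound 4 `Cc1cc(Br)c2nc(-c3nnc(-c4ccc(Br)cc4)o3)cn2c1`, has bromo in place of chloro on an aromatic carbon, the change from 4-chlorophenyl to 4-bromophenyl: bromo in place of chloro on an aromatic carbon.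

Among the measured compounds shown here, only one measured step bears on this change. That step, a 3.0-fold higher number from compound 2 to compound 3 (0.48 log units; beyond the scatter), is modest and puts chloro in place of hydrogen at the same place on the ring. It shows that this assay responds to a substituent there, but it starts from hydrogen. For the measured compounds named here, no measured pair exchanges one halogen for another, so the data give no direct size for this swap. No change beyond the scatter is therefore expected, and compound 3 at 43500 nM is the anchor. The expected change is a 1.0-fold lower number from compound 3 to compound 4 (0.02 log units; within the scatter), with no firm direction. For compound 4 the estimated value is 42000 nM, with an expected range from 19000 nM to 90000 nM.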

Compound 4, half-maximal inhibitory concentration: 23400 nM
For compound 4 the middle estimate is 1.8-fold (0.25 log units) above the measured one; measured number inside the range.
By their numbers in this assay, from the lowest: compounds 2, 4, 1 and 3 (each within the scatter of the next, the first and the last beyond it).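

Among the compounds shown here, compound 4 gives the first direct exchange of one halogen for another on this aromatic carbon, and in this assay the swap reads as a 1.9-fold lower number from compound 3 to compound 4 (0.27 log units; within the scatter), which does not separate bromo from chloro. It also gives a second substituent to set against hydrogen at the same place: a 1.6-fold higher number from compound 2 to compound 4 (0.21 log units; within the scatter) stays within the scatter, whereas a 3.0-fold higher number from compound 2 to compound 3 (0.48 log units; beyond the scatter) lies beyond it, so the step seen earlier with chloro does not carry over to bromo at the same standing, and these compounds do not show a single rule for halogen in place of hydrogen here. Nothing in the data shown accounts for this reading of the two halogens.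

With only hydrogen, chloro and bromo shown on this carbon, it remains open how the assay would read fluoro, a methoxy group or an amine at the same place. Going by these compounds, it also remains open whether bromo and chloro would read alike on the core of compound 1, which carries no bromo on its fused rings.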